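Silyl Ether in Place of a Methyl on a Flavone Oxygen

The source may hold more compounds than are shown below. What is called first, only, known or untested is meant among the compounds shown, and "the series" means these compounds.

Four closely related compounds are compared here. Compound 1 `COc1cc(-c2cc(=O)c3cc(O)ccc3o2)cc(OC)c1OC` and compound 2 `COc1cc(-c2cc(=O)c3ccc(O)cc3o2)cc(OC)c1OC` are built from the same atoms joined differently; the difference between the two cores is not broken down here. Compound 3 `COc1cc(-c2cc(=O)c3cc(O)ccc3o2)cc(OC)c1O[Si](C)(C)C(C)(C)C` comes from compound 1 through one change: a group of 7 heavy atoms (6 carbon, 1 silicon; no ring) in place of one carbon atom, on an oxygen on an aromatic ring. Compound 4 `COc1cc(-c2cc(=O)c3ccc(O)cc3o2)cc(OC)c1O[Si](C)(C)C(C)(C)C`, which has not yet been measured, comes from compound 2 through the same change: a group of 7 heavy atoms (6 carbon, 1 silicon; no ring) in place of one carbon atom, on an oxygen on an aromatic ring. The surroundings of the changed position are described in the same words for both pairs, so this is the same change made on two different cores.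

The measurement is a functional assay on Malme-3M cells (Homo sapiens) for cytotoxicity, read by MTT assay, with a stated time of 6 days; a lower number here means that less compound is needed, a higher number that more compound is needed for the effect. In this assay compound 1 gives only a limit, > 25 ug/mL. Compound 2 also gives only a limit in this assay, > 25 ug/mL. Compound 3, however, gives a measured number in this assay, 5.3 ug/mL. The step of an at least 4.7-fold lower number from compound 1 to compound 3 (0.67 log units; beyond the scatter) is thus at least modest, and its full size cannot be fixed because of the limit of > 25 ug/mL in this assay, at which 2 of the 3 values shown sit.

Since compound 2 starts at the same limit as compound 1, the expectation is that the step of an at least 3.5-fold lower number from compound 2 to compound 4 (0.55 log units; beyond the scatter) will be of a size similar to the measured step of an at least 4.7-fold lower number from compound 1 to compound 3 (0.67 log units; beyond the scatter). Compound 4 is therefore expected to give about 7 ug/mL in this assay, with a likely range from 3 ug/mL to 20 ug/mL.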

Compound 4, concentration for half-maximal effect: > 25 ug/mL
Compound 4: a limit, no number; the forecaster's own chance of this, stated with the estimate: 25%; middle value at least 3.5-fold (0.55 log units) away from the limit.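

Compound 4 gives only a limit in this assay, > 25 ug/mL. Compound 2 is also a limit there, so no step from one to the other can be read: the limit of > 25 ug/mL in this assay, at which 3 of the 4 values shown sit.

The compounds shown leave open whether the group replacing the methyl changes the number at all on the core of compound 2, as it does on the core of compound 1.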